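Chloro Enters the Shared Core of Compound 2

The compounds below may be only part of what the source reports. "The series", "measured", "known", "first", "only" and "open" are said of these compounds alone.

Compound 2 `CC(C)(C)/N=C(\NC#N)Nc1ccccn1` carries a tert-butyl group on the double-bonded nitrogen of the shared core. In a functional assay on the whole organism (blood, strain Wistar-Okamoto) with Rattus norvegicus as the target, with a stated time of 5 days (a lower number here means that less compound is needed, a higher number that more compound is needed for the effect), compound 2 gives only a limit, > 20 mg/kg, and no number. Compound 1 `N#CN/C(=N\C1CCCCC1)Nc1ccccn1`, with cyclohexyl in that place, likewise gives only a limit in this assay, namely > 35 mg/kg. Within the data shown here, the single measured step, a step that the two limits leave unreadable from compound 1 to compound 2, therefore cannot be read, since both values sit at limits: the limit of > 20 mg/kg in this assay, at which 1 of the 2 values shown sits, and (the limit of > 35 mg/kg in this assay, at which 1 of the 2 values shown sits). Compound 3 `CC(C)(C)/N=C(\NC#N)Nc1ccc(Cl)cn1` differs from compound 2 by chloro in place of hydrogen on an aromatic carbon. Among the measured compounds shown here, no measured step bears on this change, and with both known values being limits, no direction beyond the scatter can be drawn for this assay. Compound 3 is expected to give about 20 mg/kg in this assay, with a range from 5 mg/kg to 60 mg/kg. That estimate corresponds to an expected step of a number no higher from compound 2 to compound 3 (the limit leaves the size open).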

Compound 3, minimum effective dose: 25 mg/kg
The estimate for compound 3 lay 1.3-fold (0.10 log units) below the measured number, and the stated range covers the measured number.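

Compound 2 has only a limit in this assay, and the step to compound 3, with chloro in place of hydrogen, cannot be read. The compounds shown leave open whether chloro on that aromatic carbon changes the dose needed, and how tert-butyl compares with cyclohexyl.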